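The source may hold more compounds than are shown below. What is called first, only, known or untested is meant among the compounds shown, and "the series" means these compounds.

Measured so far in a functional assay on MCF7 cells (Homo sapiens) for antiproliferative activity, read by MTT assay, with a stated time of 48 h; on this read-out lower numbers stand for stronger inhibition and higher numbers for weaker inhibition:
compound 1 `COc1ccc(-c2csc(N3N=C(c4ccc(C)cc4)CC3c3ccc4c(c3)OCCO4)n2)cc1`: 2680 nM
compound 2 `COc1ccc(C2=NN(c3nc(-c4ccc(OC)cc4)cs3)C(c3ccc4c(c3)OCCO4)C2)cc1`: 2730 nM

Compound 1 and compound 2 give numbers within the scatter of each other, so neither can be set apart from the other on this read-out. Compound 3 `Cc1ccc(C2=NN(c3nc(-c4ccc(Br)cc4)cs3)C(c3ccc4c(c3)OCCO4)C2)cc1` is not yet measured. Relative to compound 1 its change is bromo in place of methoxy on an aromatic carbon. For the measured compounds named here, the only measured step that touches this site is the one from compound 1 to compound 2, a methoxy in place of methyl on the same aromatic carbon, which came out as a 1.0-fold higher number from compound 1 to compound 2 (0.01 log units; within the scatter). Going by the values given here, that step suggests the group at this aromatic carbon matters little for this assay, but bromo has no precedent here, so the expectation is loose. For compound 3 the expected step is a 1.0-fold higher number from compound 1 to compound 3 (0.02 log units; within the scatter), that is, no change beyond the scatter. Compound 3 is therefore estimated at 2800 nM, with a range of 1200 nM to 6500 nM.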

Compound 3, half-maximal inhibitory concentration: 1590 nM
Compound 3: middle estimate off by 1.8-fold (0.25 log units), on the high side; low and high end bracket the measured number.
By their numbers in this assay, from the lowest: compounds 3, 1 and 2 (each within the scatter of the next).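

In this assay, bromo in place of methoxy on an aromatic carbon of the 4-methoxyphenyl ring gives a 1.7-fold lower number from compound 1 to compound 3 (0.23 log units; within the scatter) and so cannot be set apart from no change. The methoxy oxygen and its hydrogen-bond acceptor are therefore not required at this carbon to hold the read-out at the level of compound 1, and a single bromine atom serves there just as well on this read-out. No other measurement is available that would explain this result.

Still open, going by these compounds, is whether an amine, a carboxylic acid or a longer chain such as butoxy on this carbon would move the number beyond the scatter. The compounds shown also leave open whether bromo would read the same on another carbon of this ring.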